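The compounds below may be only part of what the source reports. "The series", "measured", "known", "first", "only" and "open" are said of these compounds alone.

Compound 1 `COc1ccc(C(=O)O)cc1OCCCCOc1ccc(C(=O)CC(C)C)c(O)c1C` gives the largest response of the three compounds tested in an assay on HEK293 cells for positive allosteric modulation of metabotropic glutamate receptor 2 (Rattus norvegicus), read by thallium flux, with a stated time of 2.5 min (a lower number here means a smaller maximal response, a higher number a larger maximal response), at 89.7%. Compound 2 `Cc1c(OCCCCOc2cccc(C(=O)O)c2)ccc(C(=O)CC(C)C)c1O` gives 84.5% in this assay, and the change of a number 5.2 percentage points lower from compound 1 to compound 2 (within the scatter) stays within the scatter. Compound 3 `CC(=O)c1ccc(OCCCCOc2ccc(F)c(C(=O)O)c2)c(C)c1O` gives 75.5% in this assay, which lies beyond the scatter from compound 1, but compound 3 differs from compound 1 in more than one place, so no single step can be read from that pair. Compound 4 `CCC(=O)c1ccc(OCCCCOc2cc(C(=O)O)ccc2OC)c(C)c1O` differs from compound 1 by methyl in place of isopropyl on a saturated chain carbon bound to a carbonyl carbon. Among the compounds with values here, no measured step touches this change; the only shortening of the ketone chain in the set, in compound 3, comes together with other changes. For compound 4 a step of a number 9.7 percentage points lower from compound 1 to compound 4 (within the scatter) is therefore expected, and its response in this assay is estimated at 80%, from 62% to 95%.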

Compound 4, largest response reached (reported as percent of maximum), in percent of the reference or control that the assay uses: 72.6%
Compound 4: middle estimate off by 7.4 percentage points, on the high side; the range from low to high includes it.
By their numbers in this assay, from the lowest: compounds 4, 3, 2 and 1 (each within the scatter of the next, the first and the last beyond it).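

The ketone chain now has a step of its own in this assay: methyl in place of isopropyl on a saturated chain carbon bound to a carbonyl carbon gives a number 17.1 percentage points lower from compound 1 to compound 4 (beyond the scatter), so the maximal response is sensitive to this position, unlike the earlier change from methoxy to hydrogen, which stayed within the scatter. Nothing available explains this drop. From the compounds shown here alone, it remains open whether a longer chain or a cyclohexyl group here would keep the response, and whether the drop also holds without the methoxy.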